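Secondary amide exchanged for a pyrrolidine ring

The source may report more compounds than this note shows. Statements on the series, on what has been measured and on what is new or still open speak of the compounds shown alone.

Compound 3 `CC(C)NC(=O)/C=C1\CCc2ccc(F)cc21` stands at the top of the three measured compounds in a functional assay on the whole organism with Rattus norvegicus as the target, at a dose of 20 mg/kg by the oral route (a higher number here means more inhibition at the dose given (going by the name of the read-out), a lower number less inhibition), where compound 3 gives 45%. Its nearest neighbour on the numbers is compound 2 `O=C(/C=C1\CCc2ccc(F)cc21)NCCO`, which in this assay gives 42%, and the step of a number 3 percentage points higher from compound 2 to compound 3 (within the scatter) is within the scatter. Furthest away is compound 1 `O=C(/C=C1\CCc2ccc(F)cc21)NCC1CC1`, which in this assay gives 0%; the step of a number 45 percentage points higher from compound 1 to compound 3 (beyond the scatter) and the step of a number 42 percentage points higher from compound 1 to compound 2 (beyond the scatter) both lie beyond the scatter.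

Compound 4 `O=C(/C=C1\CCc2ccc(F)cc21)N1CCCC1` differs from compound 3 in one place: pyrrolidin-1-yl in place of isopropylamino on a carbonyl carbon. Among the measured compounds shown here, none of the measured steps covers this kind of change. The steps from compound 1 to compound 3 and from compound 2 to compound 3 vary the group on the amide-type nitrogen while keeping the amide hydrogen; the change to compound 4 removes that hydrogen and closes the nitrogen into a ring. The measured steps show that variation at this end of the molecule can move the read-out in this assay a long way, as in a number 45 percentage points higher from compound 1 to compound 3 (beyond the scatter), or hardly at all, as in a number 3 percentage points higher from compound 2 to compound 3 (within the scatter).

The account therefore expects for compound 4 a step of a number 20 percentage points lower from compound 3 to compound 4 (beyond the scatter), a modest fall with wide uncertainty. Compound 4 is estimated to give 25% in this assay, with a range from 0% to 55%.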

Compound 4, a percentage reported as inhibition, in the whole organism at one dose (the size of the read-out at that dose, not a potency): 10%
For compound 4 the middle estimate is 15 percentage points above the measured one, within the range that was stated.
By their numbers in this assay, from the lowest: compounds 1 and 4 (each within the scatter of the next); then compounds 2 and 3 (each within the scatter of the next).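

Pyrrolidin-1-yl on the carbonyl carbon is the first change in this series that takes away the amide hydrogen and closes the nitrogen into a ring, and in this assay it gives a number 35 percentage points lower from compound 3 to compound 4 (beyond the scatter) and a number 32 percentage points lower from compound 2 to compound 4 (beyond the scatter) as well. The amide hydrogen alone does not set the read-out, however: compound 1 keeps it, yet the comparison with the ring amide gives a number 10 percentage points higher from compound 1 to compound 4 (within the scatter) and so goes against any simple rule that compounds with the amide hydrogen score well at this dose. Nothing available explains the fall in the read-out with this change.

The compounds shown leave open whether the loss of the amide hydrogen or the ring itself goes with the lower read-out, a question that an open-chain dimethylamino or diethylamino group on the carbonyl carbon could separate. They also leave open how a piperidin-1-yl or morpholin-4-yl ring in the same place would behave in this assay and whether a cyclopentylamino group, which keeps the amide hydrogen, would stand with compound 3 or with compound 1 on these numbers.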